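From 4-chlorophenyl to 3,5-dichlorophenyl in compound 4

The compounds below may be only part of what the source reports. "The series", "measured", "known", "first", "only" and "open" are said of these compounds alone.

In a functional assay on NCI-H727 cells (Homo sapiens) for cytotoxicity, read by cell counting, with a stated time of 48 h (on this read-out higher numbers stand for weaker inhibition and lower numbers for stronger inhibition), compound 1 (`Clc1ccc(-n2cc(COc3cccc4cnc(Nc5cccc(Cl)c5)nc34)nn2)cc1`) gives > 25000 nM. That value is a limit and not a number. It sits at the high end of the values shown, so every step from compound 1 is known only as a bound.

Compound 4 (`Clc1cccc(Nc2ncc3cccc(OCc4cn(-c5cc(Cl)cc(Cl)c5)nn4)c3n2)c1`) carries 3,5-dichlorophenyl in place of 4-chlorophenyl on an aromatic nitrogen of a five-membered aromatic ring with 3 nitrogen: 3,5-dichlorophenyl in place of 4-chlorophenyl on an aromatic nitrogen.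

Two other compounds differ at that same place. Compound 2 (`Clc1cccc(Nc2ncc3cccc(OCc4cn(Cc5c(Cl)cccc5Cl)nn4)c3n2)c1`), with 2,6-dichlorobenzyl, gives 5000 nM, and compound 3 (`Clc1cccc(Nc2ncc3cccc(OCc4cn(-c5ccc(Br)cc5)nn4)c3n2)c1`), with 4-bromophenyl, gives 8000 nM. These changes amount to an at least 5.0-fold lower number from compound 1 to compound 2 (0.69 log units; beyond the scatter) and an at least 3.1-fold lower number from compound 1 to compound 3 (0.49 log units; beyond the scatter), both beyond the scatter. Between them lies a 1.6-fold higher number from compound 2 to compound 3 (0.20 log units; within the scatter), which is within the scatter.

On those two steps, a move of similar size toward a lower number is expected in this assay, though a second limit remains possible. The expected step is an at least 3.1-fold lower number from compound 1 to compound 4 (0.49 log units; beyond the scatter). For compound 4 the estimate is 8000 nM, with an expected range of 3000 nM to 25000 nM.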

Compound 4, half-maximal inhibitory concentration: 7000 nM
Estimate against measurement, compound 4: 1.1-fold (0.06 log units) above, within the range that was stated.
By their numbers in this assay, from the lowest: compounds 2, 4 and 3 (each within the scatter of the next). At a limit, above all of these: compound 1.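

In this assay, the step to 3,5-dichlorophenyl is an at least 3.5-fold lower number from compound 1 to compound 4 (0.55 log units; beyond the scatter), so a phenyl group with two chlorine atoms on this aromatic nitrogen also gives a measurable number, as 2,6-dichlorobenzyl and 4-bromophenyl did. Set against those two groups, the new one cannot be told apart: the steps are a 1.1-fold lower number from compound 3 to compound 4 (0.06 log units; within the scatter) and a 1.4-fold higher number from compound 2 to compound 4 (0.15 log units; within the scatter), both within the scatter. Compound 1 alone stands at a limit, so its step gives a bound and not a true size: the limit of > 25000 nM in this assay, at which 1 of the 4 values shown sits.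

The compounds shown leave open how far compound 1 really lies from the other three, and whether this place tolerates anything other than an aromatic group bearing halogen. An amine or a carboxylic acid on the phenyl ring, or a longer chain on the nitrogen, remains to be seen here.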